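The compounds below may be only part of what the source reports. "The series", "measured", "known", "first", "only" and "open" are said of these compounds alone.

Measured in a functional assay on HCT-116 cells (Homo sapiens) for inhibition, read by MTT assay, with a stated time of 48 h; a higher number here means a weaker inhibitor, a lower number a stronger inhibitor:
- compound 1 `COc1ccc(N(C)c2nc(C)nc3ccccc23)cc1C(=O)OCC[Se]C#N`: 951 nM
- compound 2 `COc1ccc(N(C)c2nc(C)nc3ccccc23)cc1C(=O)OCCC[Se]C#N`: 720 nM
- compound 3 `COc1ccc(N(C)c2nc(C)nc3ccccc23)cc1C(=O)NCC[Se]C#N`: 313 nM

Compound 3 gives the lowest number of the three, with a 2.3-fold lower number from compound 2 to compound 3 (0.36 log units; beyond the scatter) and a 3.0-fold lower number from compound 1 to compound 3 (0.48 log units; beyond the scatter). Within the chain, a 1.3-fold lower number from compound 1 to compound 2 (0.12 log units; within the scatter). Compound 4 `COc1ccc(N(C)c2nc(C)nc3ccccc23)cc1[Se]C` differs at the aromatic carbon ortho to a methoxy group: a group of 2 heavy atoms (1 carbon, 1 selenium; no ring) in place of a group of 8 heavy atoms (4 carbon, 2 nitrogen, 1 oxygen, 1 selenium; no ring), on an aromatic carbon. These measured steps bear on this change only loosely, since each alters the group beyond the carbonyl carbon or the chain, and none replaces the whole group on the aromatic carbon. Their small size therefore sets no limit here. A lower number is tentatively expected, with wide uncertainty. The expected step is a 3.9-fold lower number from compound 3 to compound 4 (0.59 log units; beyond the scatter). The estimate for compound 4 is 80 nM, with an expected range from 6 nM to 900 nM.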

Compound 4, half-maximal inhibitory concentration: 28 nM
Beside the measured number, compound 4's estimate is 2.9-fold (0.46 log units) above it; the range from low to high includes it.
By their numbers in this assay, from the lowest: compound 4; then compound 3; then compounds 2 and 1 (each within the scatter of the next).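

In this assay the methylseleno group on the aromatic carbon, in place of the whole side group, gives an 11-fold lower number from compound 3 to compound 4 (1.05 log units; beyond the scatter) and, from the esters, a 26-fold lower number from compound 2 to compound 4 (1.41 log units; beyond the scatter) and a 34-fold lower number from compound 1 to compound 4 (1.53 log units; beyond the scatter) with all three large. Neither the carbonyl, the chain nor the nitrile is therefore needed for a low number at this position. Nothing available explains the size of these steps.

As far as these compounds go, it remains open whether selenium itself matters, which a methylthio group on the same carbon would test. A nitrile on selenium directly at this carbon is likewise untested among these compounds.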